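Phenyl for Benzyl at the Aryl Ether Oxygen

This account rests on a few compounds, and the source may have more. Where it says the series, first, only, none or still open, it means among the compounds named here.

Measured compounds:
compound 1 `NC(=O)[C@@H]1CC[C@H](c2cccc(OCc3ccccc3)c2)N1` — > 100000 nM
compound 2 `O=C1NCCC1NCc1ccc(OCc2ccccc2F)cc1` — 126000 nM
compound 3 `COc1cc([C@H]2CC[C@@H](C(N)=O)N2)ccc1OCc1ccccc1F` — 63100 nM

All three compounds were tested in an assay on HEK293 cells for inhibition of sodium channel protein type 3 subunit alpha (Homo sapiens), read by electrophysiology, with a stated time of 3.5 min; a higher number here means a weaker inhibitor, a lower number a stronger inhibitor. In this assay compound 2 gives 126000 nM and compound 3 gives 63100 nM; the two values lie within the usual scatter of each other, so neither is set apart from the other. For compound 1 the result is a limit and not a number: > 100000 nM. Compound 1 therefore stands at the limit of > 100000 nM in this assay, at which 1 of the 3 values shown sits, and no sharper position can be given for it.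

Compound 4 (`NC(=O)[C@@H]1CC[C@H](c2cccc(Oc3ccccc3)c2)N1`) has not yet been measured. It differs from compound 1 in one place: phenyl in place of benzyl on an oxygen on an aromatic ring. For the measured compounds named here, no pair of measured compounds shows this change on its own, so no step can be read from the data. Compound 4 is expected to stay weak, with an estimate of 90000 nM and a range from 20000 nM to 300000 nM. The expected step of an at least 1.1-fold lower number from compound 1 to compound 4 (0.04 log units; that floor lies within the scatter) is an expectation of no shift beyond the scatter, though because compound 1 sits at the limit of > 100000 nM in this assay, at which 1 of the 3 values shown sits, the step cannot be pinned down.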

Compound 4, half-maximal inhibitory concentration: > 100000 nM
Compound 4: a limit, no number (the forecaster's own chance of this, stated with the estimate: 60%); at least 1.1-fold (0.04 log units) between middle value and limit.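

In this assay compound 4 gives > 100000 nM as a limit and not a number. For the compounds shown here, with compound 1 also at a limit, no step between compound 1 and compound 4 can be read: the limit of > 100000 nM in this assay, at which 2 of the 4 values shown sit.

The compounds shown leave open whether phenyl in place of benzyl on an oxygen on an aromatic ring changes inhibition at all.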